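Swapping a propargyl ether for a tosyl ester: what to expect

The source may hold more compounds than are shown below. What is called first, only, known or untested is meant among the compounds shown, and "the series" means these compounds.

Compound 1 `C#CCOc1cc(/C=C/C(=O)c2ccc(OC)c3c2OC(C)(C)C=C3)ccc1OC` gives > 10000 nM in a functional assay on K562 cells (Homo sapiens) for cytotoxicity, read by MTT assay; on this read-out higher numbers stand for weaker inhibition and lower numbers for stronger inhibition; this is a limit of the assay, not a number.
Compound 2 `COc1ccc(/C=C/C(=O)c2ccc(OC)c3c2OC(C)(C)C=C3)cc1OS(=O)(=O)Cc1ccccc1` gives > 10000 nM in this assay; this too is only a limit.

Compound 1 therefore stands only at a limit, and both values shown sit there (the limit of > 10000 nM in this assay, at which 2 of the 2 values shown sit). The step that the two limits leave unreadable from compound 1 to compound 2 cannot be sized, since both of its ends are limits. Compound 3 `COc1ccc(/C=C/C(=O)c2ccc(OC)c3c2OC(C)(C)C=C3)cc1OS(=O)(=O)c1ccc(C)cc1` differs from compound 1 in one place: (4-methylphenyl)sulfonyl in place of propargyl on an oxygen on an aromatic ring. Within the data shown here, the only measured step that resembles this change is the one from compound 1 to compound 2, where benzylsulfonyl enters on the same oxygen, and it left the read-out at the limit. Because both measured values sit at the limit (the limit of > 10000 nM in this assay, at which 2 of the 2 values shown sit), compound 3 is expected to remain weak as well. The step that the limit leaves unreadable from compound 1 to compound 3 is expected to stay unreadable. Compound 3 is estimated at 20000 nM, between 8000 nM and 60000 nM.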

Compound 3, half-maximal inhibitory concentration: 7850 nM
Estimate against measurement, compound 3: 2.5-fold (0.41 log units) above; the measured number lies below the stated range.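

Among these compounds, on the oxygen on an aromatic ring, the (4-methylphenyl)sulfonyl group gives the only value here in this assay that is a number and not a limit: compound 3 reads 7850 nM. Replacing propargyl with this group gives an at least 1.2-fold lower number from compound 1 to compound 3 (0.10 log units; that floor lies within the scatter), and replacing benzyl with 4-methylphenyl on the sulfonyl sulfur gives an at least 1.2-fold lower number from compound 2 to compound 3 (0.10 log units; that floor lies within the scatter). Both are floors, and neither secures a real difference, but the position can now give a measurable reading, while the other compounds remain at the limit: the limit of > 10000 nM in this assay, at which 2 of the 3 values shown sit.

From the compounds shown here alone, the step between the two compounds at the limit cannot be read, and the true distance of each from compound 3 remains unknown. Also open, going by these compounds, is how a smaller methanesulfonyl group or a sulfonyl group carrying an amine would read on the same oxygen.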